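Swapping the Amine Ring on a Long-Lived Core

The source may report more compounds than this note shows. Statements on the series, on what has been measured and on what is new or still open speak of the compounds shown alone.

Compound 1 `Cn1cc(-c2ccc3nnc(Sc4ccc5ncc(N6CCC(N)C6)cc5c4)n3c2)cn1`: > 8.33 h
Compound 2 `Cn1cc(-c2ccc3nnc(Sc4ccc5ncc(NCCO)cc5c4)n3c2)cn1`: 3.82 h

In an ADME assay on cytosol from liver (strain IGS SD) for pharmacokinetics, with aldehyde oxidase 1 (Rattus norvegicus) as the target, read by LC-MS, with a stated time of 120 min, tested at 1 uM (on this read-out higher numbers stand for a longer-lived compound and lower numbers for a shorter-lived compound), compound 1 gives > 8.33 h, which is a limit of the assay and not a number (the limit of > 8.33 h in this assay, at which 1 of the 2 values shown sits). Compound 2 gives 3.82 h. Going by the values given here, the one measured step is an at least 2.1-fold lower number from compound 1 to compound 2 (0.33 log units; beyond the scatter). Compound 3 `Cn1cc(-c2ccc3nnc(Sc4ccc5ncc(NC6COC6)cc5c4)n3c2)cn1` carries a different change at the same place: (oxetan-3-yl)amino in place of 3-aminopyrrolidin-1-yl on an aromatic carbon. Since the only comparable replacement of the 3-aminopyrrolidin-1-yl group gave a shorter-lived compound, a modest fall is expected here too, as the step of an at least 1.6-fold lower number from compound 1 to compound 3 (0.22 log units; that floor lies within the scatter). Compound 3 is therefore estimated at 5 h, with a range from 2.5 h to 10 h.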

Compound 3, half-life: 2.15 h
Estimate against measurement, compound 3: 2.3-fold (0.37 log units) above; the whole stated range lies above it.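

In this assay, a second replacement of the 3-aminopyrrolidin-1-yl group also gives a shorter-lived compound, and this step is larger than the first: an at least 3.8-fold lower number from compound 1 to compound 3 (0.58 log units; beyond the scatter). The two replacements cannot be told apart, with a 1.8-fold lower number from compound 2 to compound 3 (0.25 log units; within the scatter), so the oxetan-3-yl and 2-hydroxyethyl groups on that nitrogen behave alike here. Compound 1 carries a limit of the assay and not a number: the limit of > 8.33 h in this assay, at which 1 of the 3 values shown sits.

As far as these compounds go, the full size of both steps from compound 1 stays open. From the compounds shown here alone, it also remains open whether a piperazin-1-yl group at this place would give a compound as long-lived as compound 1.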